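Trading tert-butyl for methyl at the assay limit

The source may report more compounds than this note shows. Statements on the series, on what has been measured and on what is new or still open speak of the compounds shown alone.

Within the data shown here, only two compounds have been read so far, and neither gives an exact number. In a functional assay on HL-60 cells (Homo sapiens) for inhibition, read by MTT assay, with a stated time of 72 h (on this read-out higher numbers stand for weaker inhibition and lower numbers for stronger inhibition), compound 1 (`COc1ccc(-c2nc(C)oc2C(=O)N2CCN(c3cccc(Cl)c3)CC2)cc1OC`) comes back as "not active" (no number reported) with no figure attached. Compound 2 (`CC(C)(C)c1nc(-c2ccccc2F)c(C(=O)N2CCN(c3cccc(Cl)c3)CC2)o1`) gives > 1000 nM in this assay and that entry is a limit of the assay, not a number. Compound 2 therefore has no exact place on the scale.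

The next compound, compound 3 (`Cc1nc(-c2ccccc2F)c(C(=O)N2CCN(c3cccc(Cl)c3)CC2)o1`), carries methyl in place of tert-butyl on an aromatic carbon and is otherwise the same as compound 2. Among the measured compounds shown here, no measured pair here shows what such a swap does in this assay so no large move in either direction is expected. The expectation leans on compound 2, whose limit of > 1000 nM is the only reference available. The expected result is a step that the limit leaves unreadable from compound 2 to compound 3 and so no step beyond the usual scatter. Compound 3 is estimated at 1800 nM with an expected range from 400 nM to 8000 nM and a real chance of a limit of the assay in place of a number.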

Compound 3, half-maximal inhibitory concentration: 39.4 nM
For compound 3 the middle estimate is 46-fold (1.66 log units) above the measured one, outside the stated range (below it).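

In this assay, the place on the five-membered aromatic ring next to the ring nitrogen and next to the ring oxygen clearly matters: with the 2-fluorophenyl group and the rest of the molecule kept the same, methyl in place of tert-butyl gives an at least 25-fold lower number from compound 2 to compound 3 (1.40 log units; beyond the scatter), a large change from one substitution. Compound 3 also supplies the first exact number among the compounds shown, so this series can now be placed on the scale rather than only at its edge. The printed step is a minimum and not an exact size, because compound 2 sits at a limit of the assay: the limit of > 1000 nM in this assay, at which 1 of the 3 values shown sits.

Methyl at this place does not settle the matter alone, since compound 1 also carries methyl there, has a different group in place of the 2-fluorophenyl group, and compound 1 gives "not active" (no number reported). From the compounds shown here alone, how an ethyl group, an isopropyl group or an amine at this place would read in this assay stays open, and so does whether the change follows the number of carbons in the group or is specific to methyl.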